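The source may report more compounds than this note shows. Statements on the series, on what has been measured and on what is new or still open speak of the compounds shown alone.

Measured in an ADME assay on TZM cells (Homo sapiens) for cytotoxicity, read by XTT assay, with a stated time of 4 days; on this read-out higher numbers stand for lower toxicity in this test and lower numbers for higher toxicity in this test:
Compound 1 `Cc1cc(N)cc(C)c1Oc1cc(Nc2ccc(C#N)cc2)c(N)cc1C(F)(F)F`: 15800 nM
Compound 2 `Cc1cc(/C=C/C#N)cc(C)c1Oc1cc(Nc2ccc(C#N)cc2)c(N)cc1[N+](=O)[O-]`: > 24400 nM (a limit)
Compound 3 `COC(=O)c1cc(N)c(Nc2ccc(C#N)cc2)cc1Oc1c(C)cc(/C=C/C#N)cc1C`: > 22800 nM (a limit)

Compound 3 has no number in this assay, only the limit > 22800 nM. Compound 4 `Cc1cc(/C=C/C#N)cc(C)c1Oc1cc(Nc2ccc(C#N)cc2)c(N)cc1C(F)(F)F` differs from it by trifluoromethyl in place of methoxycarbonyl on an aromatic carbon. For the measured compounds named here, the one measured step touching this place is a step that the two limits leave unreadable from compound 2 to compound 3, so it offers no size to carry over. Compound 1, which also bears trifluoromethyl, gives 15800 nM. Resting on that value of compound 1, a modest move towards lower numbers is expected in this assay, though it may well stay within the scatter. The expected step is an at least 1.2-fold lower number from compound 3 to compound 4 (0.10 log units; that floor lies within the scatter). For compound 4 the estimated value is 18000 nM, with an expected range of 8000 nM to 40000 nM.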

Compound 4, half-maximal cytotoxic concentration in the TZM assay: 15000 nM
Estimate against measurement, compound 4: 1.2-fold (0.08 log units) above; the range from low to high includes it.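

Trifluoromethyl at this position gives a real number in the TZM assay, where the other two compounds bearing 2-cyanoethenyl give only limits, with an at least 1.5-fold lower number from compound 3 to compound 4 (0.18 log units; that floor lies within the scatter) and an at least 1.6-fold lower number from compound 2 to compound 4 (0.21 log units; that floor lies within the scatter), both floors only. In the TZM assay, 2-cyanoethenyl in place of amino gives a 1.1-fold lower number from compound 1 to compound 4 (0.02 log units; within the scatter). In a physicochemical assay for solubility, with a stated time of 4 h, at pH 7.4 (a lower number here means a less soluble compound, a higher number a more soluble compound), compound 3 gives 1.3 ug/mL and compound 4 gives 0.24 ug/mL. Trifluoromethyl in place of methoxycarbonyl also shows a clear difference in the physicochemical assay: the measured solubility of compound 3, 1.3 ug/mL, and of compound 4, 0.24 ug/mL, a 5.4-fold lower number (0.73 log units; beyond the scatter)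

As far as these compounds go, how far the true values of compound 2 and compound 3 lie from that of compound 4 remains open. So does how a carboxylic acid or an amide at this position would read in the TZM assay and the physicochemical assay.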